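Swapping the Amide Substituent: Cyclohexyl to Benzyl

The source may report more compounds than this note shows. Statements on the series, on what has been measured and on what is new or still open speak of the compounds shown alone.

Two compounds share a core built from a dimethoxy-substituted bicyclic framework carrying an amide-bearing side chain, and differ only in the group attached to the amide nitrogen. Compound 1, with structure `CCNC(=O)CC1CCc2cc(OC)c(OC)cc21`, gives 23.6% in a functional assay on the whole organism (strain Swiss albino) for inhibition, with Mus musculus as the target, in the writhing test, with stated times of 60 min and 15 min, at a dose of 100 mg/kg by the oral route; a higher number here means more inhibition at the dose given (going by the name of the read-out), a lower number less inhibition. Compound 2, with structure `COc1cc2c(cc1OC)C(CC(=O)NC1CCCCC1)CC2`, gives 44.7% in this assay. Among the compounds with values here, the step of a number 21.1 percentage points higher from compound 1 to compound 2 (beyond the scatter) is the only measured change, and it places compound 2 at the top of the two numbers, with compound 1 as its nearest neighbour at a distance beyond the scatter.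

Compound 3, with structure `COc1cc2c(cc1OC)C(CC(=O)NCc1ccccc1)CC2`, carries the change (benzyl in place of cyclohexyl on an amide-type nitrogen). Within the data shown here, no measured step covers this exact replacement. Among the measured compounds shown here, the one step that exists shows that enlarging the group on the amide nitrogen from ethyl to a six-membered carbon ring raised the number, but it says nothing about trading a saturated ring for an aromatic one. Benzyl is close in size to cyclohexyl, so the expected step of a number 4.7 percentage points lower from compound 2 to compound 3 (within the scatter) is small, and compound 3 is estimated at 40%, with a range from 24% to 56%.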

Compound 3, a percentage reported as inhibition, in the whole organism at one dose (the size of the read-out at that dose, not a potency): 48.1%
Compound 3: middle estimate off by 8.1 percentage points, on the low side, and the stated range covers the measured number.
By their numbers in this assay, from the lowest: compound 1; then compounds 2 and 3 (each within the scatter of the next).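

Benzyl in place of cyclohexyl on an amide-type nitrogen gives a number 3.4 percentage points higher from compound 2 to compound 3 (within the scatter) in this assay, so at this position an aromatic ring and a saturated ring of the same size give numbers that cannot be told apart, although benzyl has one more carbon. Seen from the small end of the series, phenyl in place of methyl on a saturated chain carbon bound to an amide-type nitrogen gives a number 24.5 percentage points higher from compound 1 to compound 3 (beyond the scatter) and so turns ethyl into benzyl, which means that two different ring-bearing groups both stand clear of ethyl, and the gain seen with cyclohexyl is not unique to that one ring. Nothing measured here accounts for the gain over ethyl or for the close agreement of the two rings.

The compounds shown leave open how far the ring can move from the amide nitrogen, as with phenyl attached directly or a longer chain such as phenethyl. They also leave open what a substituent on the benzyl ring, such as fluorine or methoxy, would do, and whether a ring containing an amine nitrogen, such as piperidine, would fit in the same place.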